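Swapping Methylamino for Phenyl on a Shared Core

The source may report more compounds than this note shows. Statements on the series, on what has been measured and on what is new or still open speak of the compounds shown alone.

Of the compounds shown here, three with the same core have been tested in a functional assay on the whole organism (strain Sprague-Dawley CD) for inhibition, with Rattus norvegicus as the target, read by paw edema, at a dose of 10 mg/kg by the intraperitoneal route; a lower number here means a weaker effect, a higher number a stronger effect of the compound at the dose given. Compound 1 `CCOC(=O)C(=O)Nc1ccccc(C)c1=O` carries a methyl group and gives 40%. Compound 2 `CCOC(=O)C(=O)Nc1ccccc(O)c1=O` carries a hydroxy group instead and gives 5%. Compound 3 `CCOC(=O)C(=O)Nc1ccccc(NC)c1=O` carries a methylamino group and gives 73%, the highest of the three numbers, with both steps toward it beyond the scatter: a number 33 percentage points higher from compound 1 to compound 3 (beyond the scatter) and a number 68 percentage points higher from compound 2 to compound 3 (beyond the scatter).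

The next compound, compound 4 `CCOC(=O)C(=O)Nc1ccccc(-c2ccccc2)c1=O`, differs from compound 3 in one place: phenyl in place of methylamino on an aromatic carbon. The entering phenyl has no hydrogen-bond donor and no acceptor, so in that respect it is closer to the methyl of compound 1 than to the methylamino of compound 3 or the hydroxy of compound 2. The step from methyl to methylamino was large, and removing the methylamino is expected to give back a good part of that gain. A downward step of roughly that size is therefore expected in this assay, a number 38 percentage points lower from compound 3 to compound 4 (beyond the scatter), because compound 1 gives 40% with a group that likewise offers no donor or acceptor. Compound 4 is estimated at 35%, with a range from 10% to 65%.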

Compound 4, a percentage reported as inhibition, in the whole organism at one dose (the size of the read-out at that dose, not a potency): 57%
Compound 4: the middle estimate sits 22 percentage points below what was measured; low and high end bracket the measured number.
By their numbers in this assay, from the lowest: compound 2; then compound 1; then compound 4; then compound 3.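

Replacing the methylamino group with phenyl costs only a modest part of the effect in this assay, with a number 16 percentage points lower from compound 3 to compound 4 (beyond the scatter) as the step, so a group without a hydrogen-bond donor or acceptor can still give a fairly high number at this aromatic carbon. Phenyl and methyl both lack a donor and an acceptor, yet the larger group with its six-membered aromatic ring gives a modest rise, a number 17 percentage points higher from compound 1 to compound 4 (beyond the scatter) being the step, so the absence of a donor and an acceptor does not by itself fix the number at this position, and the gap to the hydroxy compound is much wider, with a number 52 percentage points higher from compound 2 to compound 4 (beyond the scatter) as the step. No measurement here gives a reason for any of these differences.

The four groups differ in more than one feature at once, so the compounds shown cannot separate the contribution of size from that of the nitrogen in the methylamino group. As far as these compounds go, a dimethylamino group, an ethyl chain or a carboxylic acid at the same carbon would test those features more directly, and the effect of each at this dose remains open.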